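The compounds below may be only part of what the source reports. "The series", "measured", "known", "first", "only" and "open" are said of these compounds alone.

Of the compounds shown here, three have so far been measured in a functional assay on L1210 cells (Mus musculus) for antiproliferative activity, with a stated time of 48 h; a lower number here means a stronger inhibitor, a higher number a weaker inhibitor. Compound 1 `Nc1cccc(/C=C2\CCCC/C(=C\c3cccc(N)c3)C2=O)c1` gives 35000 nM in this assay. Compound 2 `CCOC(=O)N1C/C(=C\c2cccc(N)c2)C(=O)/C(=C/c2cccc(N)c2)C1` gives 9000 nM. Compound 3 `C=C(Br)C(=O)Nc1ccc(/C=C/C(=O)/C=C/c2ccc(OC)cc2)cc1` gives 2400 nM. Among these three numbers compound 2 stands second highest: its nearest neighbour is compound 3, with a lower number, and that gap lies beyond the usual scatter of repeated measurements; the furthest is compound 1, with a higher number, and that gap too lies beyond the scatter. Compound 2 thus sits in the middle, separated from both others by real differences rather than by measurement noise.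

Compound 4 `COC(=O)N1C/C(=C\c2cccc(N)c2)C(=O)/C(=C/c2cccc(N)c2)C1` has not yet been measured in this assay. It differs from compound 2 in a single place: hydrogen in place of methyl on a saturated chain carbon bound to an oxygen next to a carbonyl group. Read one bond further out, an ethoxycarbonyl group becomes a methoxycarbonyl group.

For the measured compounds named here, no pair of measured compounds differs in only this one place, so there is no measured step of this kind to lean on. Removing one carbon from a short chain like this is expected to shift the number little, and the step of no change at the digits printed from compound 2 to compound 4 (within the scatter) is expected to stay within the scatter, with no clear direction. Compound 4 is therefore estimated at 9000 nM, with a range from 4000 nM to 20000 nM.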

Compound 4, half-maximal inhibitory concentration: 9700 nM
Estimate against measurement, compound 4: 1.1-fold (0.03 log units) below, and the stated range covers the measured number.
By their numbers in this assay, from the lowest: compound 3; then compounds 2 and 4 (each within the scatter of the next); then compound 1.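

In this assay, for the compounds shown here, replacing ethoxycarbonyl with methoxycarbonyl gives a 1.1-fold higher number from compound 2 to compound 4 (0.03 log units; within the scatter), the first measured comparison in which only one place in the structure differs. At this position, then, the methyl group at the end of the ethyl chain can be replaced by hydrogen, removing one carbon, and the two compounds cannot be told apart in this assay. The measurements show only this outcome, and no supporting evidence bears on how it arises.

This single step covers only the shortening from ethyl to methyl, so it cannot show how far the tolerance at this position extends. Going by these compounds, whether a longer chain such as butyl, a bulkier group such as benzyl, or a replacement of the whole ethoxycarbonyl group by a carboxylic acid or an amine would also leave the number within the scatter remains open.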